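The source may hold more compounds than are shown below. What is called first, only, known or untested is meant among the compounds shown, and "the series" means these compounds.

Measured so far:
- compound 1 `O=C(Nc1ccccc1)Nc1nc(Nc2ccc(Cl)cc2)cc(Sc2c[nH]c3ccccc23)n1`: 12600 nM
- compound 2 `O=C(Nc1ccccc1)Nc1nc(Sc2c[nH]c3ccccc23)cc(N2CCCCC2)n1`: 20900 nM

Both numbers come from a functional assay on HepG2 cells (Homo sapiens) for inhibition, with a stated time of 72 h; on this read-out lower numbers stand for stronger inhibition and higher numbers for weaker inhibition. Compound 2 has the higher of the two numbers, but the step of a 1.7-fold higher number from compound 1 to compound 2 (0.22 log units; within the scatter) is within the scatter, so the two compounds cannot be told apart on this read-out.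

Compound 3 `O=C(Nc1ccccc1)Nc1nc(Sc2c[nH]c3ccccc23)cc(N2CCN(c3ccccn3)CC2)n1` has not yet been measured. It differs from compound 2 in one place: 4-(pyridin-2-yl)piperazin-1-yl in place of piperidin-1-yl on an aromatic carbon

Going by the values given here, only one measured step touches the same aromatic carbon, the change from (4-chlorophenyl)amino to piperidin-1-yl, and that step, a 1.7-fold higher number from compound 1 to compound 2 (0.22 log units; within the scatter), stayed within the scatter. Among the compounds with values here, that is the sole guide here, so no step beyond the scatter is expected in this assay for the move to 4-(pyridin-2-yl)piperazin-1-yl. The expected step of a 1.2-fold lower number from compound 2 to compound 3 (0.06 log units; within the scatter) is therefore small. Compound 3 is estimated to give 18000 nM, with a range from 6000 nM to 55000 nM.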

Compound 3, half-maximal inhibitory concentration: 8930 nM
Compound 3: the middle estimate sits 2.0-fold (0.30 log units) above what was measured, and the stated range covers the measured number.
By their numbers in this assay, from the lowest: compounds 3, 1 and 2 (each within the scatter of the next, the first and the last beyond it).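

In this assay, the aromatic carbon carrying these groups had shown no step beyond the scatter until the move from piperidin-1-yl to 4-(pyridin-2-yl)piperazin-1-yl (a 2.3-fold lower number from compound 2 to compound 3 (0.37 log units; beyond the scatter)). So the group at this carbon can shift the read-out, if only modestly, and a group with a second ring, an aromatic one, is accepted here without any loss of inhibition. Compared with the (4-chlorophenyl)amino group, the new group cannot be told apart (a 1.4-fold lower number from compound 1 to compound 3 (0.15 log units; within the scatter)), and nothing measured here accounts for the step.

On these data alone, it remains open whether the step depends on the pyridine ring, which a 4-phenylpiperazin-1-yl group would test, or on the piperazine ring alone, which a plain piperazin-1-yl group would test. How an open-chain amine such as dimethylamino would behave at this carbon is also unknown.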